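The source may hold more compounds than are shown below. What is called first, only, known or untested is meant among the compounds shown, and "the series" means these compounds.

In a functional assay (aorta) with Rattus norvegicus as the target (a lower number here means that less compound is needed, a higher number that more compound is needed for the effect), three compounds that share one core have been measured so far. Compound 1 `COc1ccc(-c2nc(N=C(N)N)sc2-c2ccc(OC)cc2)cc1` gives 2 uM, compound 2 `C/N=C(/NC)Nc1nc(-c2ccc(OC)cc2)c(-c2ccc(OC)cc2)s1` gives 2.4 uM, and compound 3 `COc1ccc(-c2nc(CNC(=O)NC(C)C)sc2-c2ccc(OC)cc2)cc1` gives 5.7 uM. Compound 3 therefore has the highest number of the three, meaning that it takes the most compound to reach the half-maximal effect.

The next structure is compound 4 `CCN(CC)C(=O)c1nc(-c2ccc(OC)cc2)c(-c2ccc(OC)cc2)s1`, and the difference is this: diethylcarbamoyl in place of ((isopropylcarbamoyl)amino)methyl on an aromatic carbon. Put simply, diethylcarbamoyl stands in place of ((isopropylcarbamoyl)amino)methyl on an aromatic carbon, and the two 4-methoxyphenyl groups remain.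

Within the data shown here, the steps that bear on this change are those made at the same place on the core. They are a 1.2-fold higher number from compound 1 to compound 2 (0.08 log units; within the scatter), a 2.9-fold higher number from compound 1 to compound 3 (0.45 log units; beyond the scatter) and a 2.4-fold higher number from compound 2 to compound 3 (0.38 log units; beyond the scatter). All three are small, with the largest only modest, so the groups tried at this place have not moved the number far. Among the measured compounds shown here, no measured compound carries diethylcarbamoyl, however, so the data do not settle a direction. No step beyond the scatter is therefore expected in this assay, although a modest move either way would be no surprise. The estimated step is a 1.1-fold higher number from compound 3 to compound 4 (0.02 log units; within the scatter). For compound 4 the expected value is 6 uM, with an estimated range from 2 uM to 18 uM.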

Compound 4, concentration for half-maximal effect: 14 uM
Compound 4: the middle estimate sits 2.3-fold (0.37 log units) below what was measured; measured number inside the range.
By their numbers in this assay, from the lowest: compounds 1 and 2 (each within the scatter of the next); then compound 3; then compound 4.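

In this assay, among these compounds, diethylcarbamoyl is the first group at this position to stand clearly apart from all the others, with a 2.5-fold higher number from compound 3 to compound 4 (0.39 log units; beyond the scatter) and a 5.8-fold higher number from compound 2 to compound 4 (0.77 log units; beyond the scatter) and also a 7.0-fold higher number from compound 1 to compound 4 (0.85 log units; beyond the scatter). Each step is modest, but together they show that this position is less indifferent to its substituent than the first three compounds suggested, and that a group with a similar heavy-atom count can still raise the number. The change from ((isopropylcarbamoyl)amino)methyl to diethylcarbamoyl goes from 2 hydrogen-bond donors to 0, but it also alters the group in other ways, and no measurement here explains the rise.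

Going by these compounds, it remains open whether the rise belongs to the amide as such or to its two ethyl groups, which a plain primary carboxamide or an N-methyl amide at this place would help to separate. On these data alone, how this assay would respond to a simple amine, a carboxylic acid or a longer chain on this aromatic carbon also remains unknown, as does whether any such group could bring the number below those of compound 1 and compound 2.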